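Fluoro Addition on a Shared Carbamate Series Against Pancreatic Cells

A few compounds are considered here, and "the series" means these few. Any claim that something is new, unique, unknown or untested is made for them only; others in the source may bear on it.

Of the compounds shown here, three from one series have been tested in a functional assay on PANC-1 cells (Homo sapiens) for inhibition, read by MTT assay, with a stated time of 24 h, tested at 10 uM; a higher number here means more inhibition at the concentration tested (going by the name of the read-out), a lower number less inhibition. Compound 1 `CC(C)=CCC1Cc2c(OC(=O)Nc3ccccc3F)cc(=O)n(CCCO)c2CC1(C)C` gives 0% in this assay. Compound 2 `CC(C)=CCC1Cc2c(OC(=O)Nc3ccc(F)cc3F)cc(=O)n(CCCO)c2CC1(C)C` gives 0%, and compound 3 `CC(C)=CCC/C(C)=C/CC1Cc2c(OC(=O)Nc3ccccc3F)cc(=O)n(CCCO)c2CC1(C)C` gives 0%. Compound 4 `CC(C)=CCC/C(C)=C/CC1Cc2c(OC(=O)Nc3ccc(F)cc3F)cc(=O)n(CCCO)c2CC1(C)C` has not yet been measured.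

Compound 3 differs from compound 1 by 3-methylbut-2-en-1-yl in place of hydrogen on a saturated chain carbon bound to a double-bonded chain carbon. Against that background, the change from compound 1 to compound 2 is fluoro in place of hydrogen on an aromatic carbon, and this step gave no change at the digits printed from compound 1 to compound 2 (within the scatter). The step from compound 1 to compound 3 likewise gave no change at the digits printed from compound 1 to compound 3 (within the scatter).

The change from compound 3 to compound 4 is fluoro in place of hydrogen on an aromatic carbon, the same change as from compound 1 to compound 2, made on the larger core. Because the earlier step gave no change at the digits printed from compound 1 to compound 2 (within the scatter), and because compound 3 itself gives 0%, the expected step for this assay is no change at the digits printed from compound 3 to compound 4 (within the scatter). Compound 4 is accordingly estimated to give 0% in this assay, with an expected range from -5% to 10%.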

Compound 4, a percentage reported as inhibition, at one concentration (the size of the read-out at that concentration, not a potency): 15.6%
Estimate against measurement, compound 4: 15.6 percentage points below; the measured number lies above the stated range.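

In this assay, the fluoro addition gave a number 15.6 percentage points higher from compound 3 to compound 4 (beyond the scatter), so on these two cores the change did not carry across with the same outcome: the same change on two cores in this assay, no change at the digits printed (within the scatter) from compound 1 to compound 2 and a number 15.6 percentage points higher (beyond the scatter) from compound 3 to compound 4, 15.6 percentage points apart, beyond the scatter of two such steps. Read along the other edge, the 3-methylbut-2-en-1-yl addition gave a number 15.6 percentage points higher from compound 2 to compound 4 (beyond the scatter), and that step also departs from its earlier counterpart: the same change on two cores in this assay, no change at the digits printed (within the scatter) from compound 1 to compound 3 and a number 15.6 percentage points higher (beyond the scatter) from compound 2 to compound 4, 15.6 percentage points apart, beyond the scatter of two such steps. Together, these steps show that in this set of four the two changes move the reading only when both are present, but they rest on a single modest reading at one concentration and show neither why this happens nor whether it would hold on any other core.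

The compounds shown leave open whether a chloro group on the same aromatic carbon would give a similar step on the larger core. They also leave open how an amine in place of the hydroxyl on the chain would alter the reading.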